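Varying the Ester Side Chain of a Naphthoquinone Core

The source may hold more compounds than are shown below. What is called first, only, known or untested is meant among the compounds shown, and "the series" means these compounds.

Compound 1 `COCCO[C@H](CC=C(C)C)C1=CC(=O)c2c(O)ccc(O)c2C1=O`: 43200 nM
Compound 2 `CC(C)=CC[C@@H](OC(=O)C1CCOC1)C1=CC(=O)c2c(O)ccc(O)c2C1=O`: 47500 nM

In a functional assay on DU-145 cells (Homo sapiens) for cytotoxicity, read by MTT assay (on this read-out higher numbers stand for weaker inhibition and lower numbers for stronger inhibition), compound 1 gives 43200 nM and compound 2 gives 47500 nM. Compound 2 stands alongside compound 1: the step of a 1.1-fold higher number from compound 1 to compound 2 (0.04 log units; within the scatter) lies within the scatter, so the two cannot be told apart. Compound 3 `CCC(C)(O)CC(=O)O[C@H](CC=C(C)C)C1=CC(=O)c2c(O)ccc(O)c2C1=O` differs from compound 2 by 2-hydroxy-2-methylbutyl in place of oxolan-3-yl on a carbonyl carbon. Within the data shown here, the one measured step also exchanged the side group on the shared core and moved the number little, so no step beyond the scatter is expected here. Compound 3 is therefore estimated at 45000 nM in this assay, between 20000 nM and 100000 nM. That estimate means an expected step of a 1.1-fold lower number from compound 2 to compound 3 (0.02 log units; within the scatter).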

Compound 3, half-maximal inhibitory concentration: 16000 nM
Beside the measured number, compound 3's estimate is 2.8-fold (0.45 log units) above it; measured number below the stated range.
By their numbers in this assay, from the lowest: compound 3; then compounds 1 and 2 (each within the scatter of the next).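

In this assay, among these compounds, the group on this carbonyl carbon proves able to move the number: 2-hydroxy-2-methylbutyl in place of oxolan-3-yl gives a 3.0-fold lower number from compound 2 to compound 3 (0.47 log units; beyond the scatter) and is the first change here beyond the scatter, while the comparison with the 2-methoxyethyl ether gives a 2.7-fold lower number from compound 1 to compound 3 (0.43 log units; beyond the scatter) in the same direction. The entering group has no ring and carries a hydrogen-bond donor, and these compounds cannot separate those two differences. No available measurement bears on the cause of the step. From the compounds shown here alone, it remains open whether the same chain without its hydroxyl would keep the step. A carboxylic acid or an amine at this place also remains to be seen.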